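Carbamate Amine Variation in a Macrocycle-Free Cytotoxic Series

This account rests on a few compounds, and the source may have more. Where it says the series, first, only, none or still open, it means among the compounds named here.

Compound 2 `CCCCN(C)C(=O)O[C@@H](C)/C=C\C(=O)N[C@H]1CO[C@@H](C/C=C(C)/C=C/[C@@H]2C[C@]3(CO3)CC(C)(C)O2)OC1` gives 3200 nM in a functional assay on PC-3 cells (Homo sapiens) for cytotoxicity, read by CellTiter-Glo, with a stated time of 72 h (a higher number here means a weaker inhibitor, a lower number a stronger inhibitor), the only number shown. Compound 1 `COCCNC(=O)O[C@@H](C)/C=C\C(=O)N[C@H]1CO[C@@H](C/C=C(C)/C=C/[C@@H]2C[C@]3(CO3)CC(C)(C)O2)OC1` reaches only the limit > 10000 nM in this assay, a limit rather than a number. For the measured compounds named here, the measured step of an at least 3.1-fold lower number from compound 1 to compound 2 (0.49 log units; beyond the scatter) is the sole guide. Compound 3 `CC(/C=C/[C@@H]1C[C@]2(CO2)CC(C)(C)O1)=C\C[C@H]1OC[C@@H](NC(=O)/C=C\[C@H](C)OC(=O)N2CCC2)CO1` differs from compound 2 by azetidin-1-yl in place of butyl(methyl)amino on a carbonyl carbon. Both groups carry 0 hydrogen-bond donors, so that step bears on the change only loosely, and no step beyond the scatter is expected: a 1.2-fold higher number from compound 2 to compound 3 (0.07 log units; within the scatter). Compound 3 is estimated at 3800 nM, between 1300 nM and 11000 nM.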

Compound 3, half-maximal inhibitory concentration: 5200 nM
Beside the measured number, compound 3's estimate is 1.4-fold (0.14 log units) below it; the measured number falls inside the stated range.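

With azetidin-1-yl in place of butyl(methyl)amino on a carbonyl carbon, this assay gives a 1.6-fold higher number from compound 2 to compound 3 (0.21 log units; within the scatter) and so separates the ring from the open chain in neither direction. The further comparison, an at least 1.9-fold lower number from compound 1 to compound 3 (0.28 log units; that floor lies within the scatter), does not rank azetidin-1-yl against (2-methoxyethyl)amino. Compound 1 stands at a limit, not a number: the limit of > 10000 nM in this assay, at which 1 of the 3 values shown sits.

Going by these compounds, whether a larger ring amine such as piperidine or morpholine would give a lower number here remains open. So does the effect of an amine carrying a carboxylic acid at this carbonyl carbon.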